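The Same Aryl Swap Tried on a Second Core

The source may hold more compounds than are shown below. What is called first, only, known or untested is meant among the compounds shown, and "the series" means these compounds.

Compound 1 `Cc1cccc(NNC(=O)c2cccc(NS(=O)(=O)c3cnc(O)nc3O)c2)c1` — > 20000 nM
Compound 2 `O=C(NNc1ccccc1Cl)c1cccc(NS(=O)(=O)c2cnc(O)nc2O)c1` — 1460 nM
Compound 3 `Cc1cccc(NNC(=O)c2ccccc2NS(=O)(=O)c2cnc(O)nc2O)c1` — > 20000 nM

In a functional assay on A549 cells (Homo sapiens) for antiproliferative activity, read by MTT assay, with a stated time of 24 h (on this read-out lower numbers stand for stronger inhibition and higher numbers for weaker inhibition), compound 1 reaches only the limit of the assay, > 20000 nM. Compound 2 gives 1460 nM in this assay. The change between them is 2-chlorophenyl in place of 3-methylphenyl on an amine nitrogen, and it made a step of an at least 13-fold lower number from compound 1 to compound 2 (1.13 log units; beyond the scatter). Compound 3 also sits at the limit of this assay, > 20000 nM; the two values at this limit are noted as the limit of > 20000 nM in this assay, at which 2 of the 3 values shown sit. Compound 3 has the same atoms as compound 1 joined differently, and the difference between the two cores is not broken down here.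

Compound 4 `O=C(NNc1ccccc1Cl)c1ccccc1NS(=O)(=O)c1cnc(O)nc1O` is not yet measured. It differs from compound 3 by 2-chlorophenyl in place of 3-methylphenyl on an amine nitrogen, the same change as from compound 1 to compound 2, at the same kind of place. Since compound 3 is known only as a limit, the starting point for the step is uncertain, so compound 4 is expected to improve by an at least 6.6-fold lower number from compound 3 to compound 4 (0.82 log units; beyond the scatter), in keeping with an at least 13-fold lower number from compound 1 to compound 2 (1.13 log units; beyond the scatter). Compound 4 is therefore estimated at 3000 nM, between 800 nM and 20000 nM.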

Compound 4, half-maximal inhibitory concentration: 5480 nM
The estimate for compound 4 lay 1.8-fold (0.26 log units) below the measured number; the range from low to high includes it.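

In this assay, the same aryl exchange gives an at least 3.6-fold lower number from compound 3 to compound 4 (0.56 log units; beyond the scatter), so the change lowers the number on the core of compound 3 as it did on the core of compound 1. This shows that the direction of the step carries over to the second core, but it does not show that the size of the step carries over, because both starting compounds are known only as limits: the same change on two cores in this assay, an at least 13-fold lower number (1.13 log units; beyond the scatter) from compound 1 to compound 2 and an at least 3.6-fold lower number (0.56 log units; beyond the scatter) from compound 3 to compound 4; the limit leaves it open whether they differ Two pairs are also too few to establish a rule for the whole series, and the limit remains common among the values shown: the limit of > 20000 nM in this assay, at which 2 of the 4 values shown sit.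

The compounds shown leave open whether the effect depends on the chlorine itself, since a plain phenyl or a 2-methylphenyl on the same amine nitrogen does not appear among them. They also leave open how an aryl ring carrying a methoxy group, an amine or a carboxylic acid would behave on either core.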